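This account rests on a few compounds, and the source may have more. Where it says the series, first, only, none or still open, it means among the compounds named here.

Compound 3 `Cc1cc(-c2ccsc2)cn2c(CSCCc3ccccc3)cnc12` is known in an ADME assay on HEL cells (Homo sapiens) for cytotoxicity, with a stated time of 3 days (a lower number here means that less compound is tolerated, a higher number that more compound is tolerated), only through a limit of the measurement: in this assay compound 3 gives >= 4 ug/mL. For comparison, compound 1 `Cc1cc(-c2ccccc2)c2ncc(CSCCc3ccccc3)n2c1` gives 20 ug/mL in this assay, and compound 2 `Cc1cc(-c2cccc([N+](=O)[O-])c2)c2ncc(CSCCc3ccccc3)n2c1` gives 100 ug/mL. Going by the values given here, the single measured step, a 5.0-fold higher number from compound 1 to compound 2 (0.70 log units; beyond the scatter), concerns a different part of the shared core. Compound 4 `Cc1cc(-c2cccs2)cn2c(CSCCc3ccccc3)cnc12` differs from compound 3 by thiophen-2-yl in place of thiophen-3-yl on an aromatic carbon. Among the compounds with values here, no measured step bears on this change, and the limit of >= 4 ug/mL in this assay, at which 1 of the 3 values shown sits, leaves the true value of compound 3 open. The step expected in this assay from compound 3 to compound 4 is therefore a step that the limit leaves unreadable from compound 3 to compound 4, a change within the scatter. Compound 4 is estimated at 10 ug/mL, with a likely range from 4 ug/mL to 40 ug/mL.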

Compound 4, minimum cytotoxic concentration: 20 ug/mL
Beside the measured number, compound 4's estimate is 2.0-fold (0.30 log units) below it, and the stated range covers the measured number.
By their numbers in this assay, from the lowest: compounds 1 and 4 (each within the scatter of the next); then compound 2.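

Going by these compounds alone, no step from compound 3 to compound 4 can be read, because compound 3 is known only through a limit: the limit of >= 4 ug/mL in this assay, at which 1 of the 4 values shown sits. The compounds shown leave open whether thiophen-2-yl in place of thiophen-3-yl changes the number in this assay at all.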